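Benzyloxy to ethyl: compound 3 to compound 4

The source may hold more compounds than are shown below. What is called first, only, known or untested is meant among the compounds shown, and "the series" means these compounds.

In an ADME assay on HCT-116 cells (Homo sapiens) for cytotoxicity, read by CellTiter-Glo, with a stated time of 72 h (a lower number here means a stronger inhibitor, a higher number a weaker inhibitor), compound 1 `CC1CCN(C2CCN(S(=O)(=O)c3cnc(Cl)s3)CC2)CC1` gives > 10000 nM, which is a limit and not a number. Compound 2 `CC1CCN(C2CCN(S(=O)(=O)c3cccc(Cl)c3)CC2)CC1` gives > 5000 nM, also a limit. Compound 3 `CC1CCN(C2CCN(S(=O)(=O)c3ccc(OCc4ccccc4)cc3)CC2)CC1` gives > 5000 nM, again a limit, so its standing is known only as a bound. Going by the values given here, no number has been read so far: the evidence consists of the limit of > 10000 nM in this assay, at which 1 of the 3 values shown sits, and (the limit of > 5000 nM in this assay, at which 2 of the 3 values shown sit).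

Compound 4 `CCc1ccc(S(=O)(=O)N2CCC(N3CCC(C)CC3)CC2)cc1` carries ethyl in place of benzyloxy on an aromatic carbon, para to a large group: ethyl in place of benzyloxy on an aromatic carbon. Among the compounds with values here, the only measured step is a step that the two limits leave unreadable from compound 1 to compound 2. It changes a different group and offers no size to carry over to this change. The expectation for compound 4 therefore rests on compound 3 at > 5000 nM, a limit. The estimated step is a step that the limit leaves unreadable from compound 3 to compound 4, and no change beyond the scatter is expected in either direction in this assay. For compound 4 the estimated value is 8000 nM, expected to fall between 4000 nM and 16000 nM, and most likely to be reported only as a limit.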

Compound 4, half-maximal inhibitory concentration: > 5000 nM
Compound 4 ended at the assay's limit; the forecaster's own chance of this, stated with the estimate: 85%; the middle value is on the limit's open side.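

Going by these compounds alone, compound 1, compound 2, compound 3 and compound 4 all stand as limits, so no step from compound 4 to any of the other three can be read. The compounds shown leave open whether any group on the sulfonyl sulfur changes the value at all.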